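The compounds below may be only part of what the source reports. "The series", "measured", "known", "first", "only" and "open" are said of these compounds alone.

Measured so far in an ADME assay on the whole organism (Rattus norvegicus, strain Sprague-Dawley) for pharmacokinetics, read by LC-MS, at a dose of 1 mg/kg by the intravenous route; a higher number here means faster removal of the compound, a lower number slower removal:
- compound 1 `Cc1cccc(F)c1CN1CCc2cc(-c3c(C)nc(C)c([C@H](OC(C)(C)C)C(=O)O)c3N3CCC(C)(C)CC3)ccc2C1`: 5.8 mL/min/kg
- compound 2 `Cc1nc(C)c([C@H](OC(C)(C)C)C(=O)O)c(N2CCC(C)(C)CC2)c1-c1ccc2c(c1)CCN(Cc1ccc(F)cc1F)C2`: 20.1 mL/min/kg
- compound 3 `Cc1nc(C)c([C@H](OC(C)(C)C)C(=O)O)c(N2CCC(C)(C)CC2)c1-c1ccc2c(c1)CCN(c1nccc(-c3cnccn3)n1)C2`: 2.1 mL/min/kg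

Compound 3 has the lowest number of the three, and its steps to both others lie beyond the scatter. Compound 4 `Cc1nc(C)c([C@H](OC(C)(C)C)C(=O)O)c(N2CCC(C)(C)CC2)c1-c1ccc2c(c1)CCN(c1nc3cnccc3s1)C2` has not been measured yet. It keeps the shared core and differs from compound 3 in one group: a group of 9 heavy atoms (6 carbon, 2 nitrogen, 1 sulfur; one five-membered aromatic ring with 2 hetero atoms, one six-membered aromatic ring with 1 hetero atom) in place of a group of 12 heavy atoms (8 carbon, 4 nitrogen; 2 six-membered aromatic rings with 2 hetero atoms each), on an amine nitrogen in a ring.

All three measured steps involve this same place, on an amine nitrogen in a ring: a 3.5-fold higher number from compound 1 to compound 2 (0.54 log units; beyond the scatter), a 2.8-fold lower number from compound 1 to compound 3 (0.44 log units; beyond the scatter) and a 9.6-fold lower number from compound 2 to compound 3 (0.98 log units; beyond the scatter). All are modest, yet beyond the scatter, so a swap here can be expected to shift this assay. Among the measured compounds shown here, no measured compound carries the incoming group, so the direction remains uncertain. For the measured compounds named here, compound 3 has the lowest number so far at 2.1 mL/min/kg, so a modest rise seems likelier than a further fall. The expected step is a 2.1-fold higher number from compound 3 to compound 4 (0.33 log units; beyond the scatter). The estimate for compound 4 is 4.5 mL/min/kg, with an expected range from 1.5 mL/min/kg to 12 mL/min/kg.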

Compound 4, clearance: 14.8 mL/min/kg
Compound 4: middle estimate off by 3.3-fold (0.52 log units), on the low side; measured number above the stated range.
By their numbers in this assay, from the lowest: compound 3; then compound 1; then compounds 4 and 2 (each within the scatter of the next).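

In this assay, the low number of compound 3 does not extend to every group with hetero atoms in its aromatic rings on this amine nitrogen, as the swap gives a 7.0-fold higher number from compound 3 to compound 4 (0.85 log units; beyond the scatter). Compound 4 cannot be separated from compound 2, whose aromatic ring is carbon only, with a 1.4-fold lower number from compound 2 to compound 4 (0.13 log units; within the scatter), and the comparison with the other carbon-only group shows a 2.6-fold higher number from compound 1 to compound 4 (0.41 log units; beyond the scatter); among these four compounds, then, hetero atoms in the aromatic rings do not by themselves go with a low number, and compound 3 remains the only one that has such a number. Nothing measured here explains these differences.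

Going by these compounds, it remains open which part of the entering group goes with the higher number, the sulfur or the five-membered ring. A version with oxygen in place of that sulfur would test the sulfur alone.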